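Sulfone-linked anilides: distal ring swap, compound 1 to 4

This account rests on a few compounds, and the source may have more. Where it says the series, first, only, none or still open, it means among the compounds named here.

Measured compounds:
- compound 1 `CC(O)(C(=O)Nc1ccc(S(=O)(=O)c2ccccc2F)cc1)C(F)(F)F`: 1300 nM
- compound 2 `CC(O)(C(=O)Nc1ccc(C#N)c(S(=O)(=O)c2ccccc2)c1)C(F)(F)F`: 2600 nM
- compound 3 `CC(O)(C(=O)Nc1ccc(C#N)c(Sc2ccccc2)c1)C(F)(F)F`: 8300 nM

In a functional assay (Cavia porcellus) with sulfonylurea receptors; K-ATP channels (Homo sapiens) as the target (a higher number here means a weaker inhibitor, a lower number a stronger inhibitor), compound 1 gives 1300 nM, the lowest of the three numbers. Compound 2 differs from compound 1 in several places. Compound 2 gives 2600 nM, and this value lies within the scatter of the value of compound 1. Compound 3 gives 8300 nM, beyond the scatter from compound 1. Within the data shown here, the only single-point step is a 3.2-fold higher number from compound 2 to compound 3 (0.50 log units; beyond the scatter), phenylsulfanyl in place of phenylsulfonyl; it concerns the linking sulfur, not the distal ring.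

Compound 4 `CC(O)(C(=O)Nc1ccc(S(=O)(=O)c2ccc(C#N)cc2)cc1)C(F)(F)F` is unmeasured. It differs from compound 1 by 4-cyanophenyl in place of 2-fluorophenyl on a sulfonyl sulfur, that is 4-cyanophenyl in place of 2-fluorophenyl on the sulfonyl sulfur. Among the measured compounds shown here, no measured step touches the distal ring, so nothing here argues for a change beyond the scatter in this assay; the wide range reflects that lack. Compound 4 is therefore expected near compound 1, with an estimated step of a 1.2-fold higher number from compound 1 to compound 4 (0.06 log units; within the scatter). The estimate for compound 4 is 1500 nM, with a range of 500 nM to 4500 nM.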

Compound 4, half-maximal inhibitory concentration: > 30000 nM
Compound 4: no number, only a limit (the forecaster's own chance of this, stated with the estimate: 5%); middle value at least 20-fold (1.30 log units) away from the limit.
By their numbers in this assay, from the lowest: compounds 1 and 2 (each within the scatter of the next); then compound 3. At a limit, above all of these: compound 4.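

In this assay the group on the sulfonyl sulfur is not a silent position: 4-cyanophenyl in place of 2-fluorophenyl gives an at least 23-fold higher number from compound 1 to compound 4 (1.36 log units; beyond the scatter), the only step shown at this place. The earlier step concerned the linking sulfur, whereas this one shows that a change in the distal group alone, with the rest of the core of compound 1 kept, can cost a large part of the inhibition. Compound 4 has no number here, only a limit of the assay: the limit of > 30000 nM in this assay, at which 1 of the 4 values shown sits.

The swap removes the fluorine and brings in the nitrile together, and the compounds shown do not separate these two changes. Also open, going by these compounds, is whether a methoxy group or an amine on this phenyl ring would stay near compound 1 or fall away like compound 4.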